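The source may hold more compounds than are shown below. What is called first, only, known or untested is meant among the compounds shown, and "the series" means these compounds.

Measured compounds:
Compound 1, `CC(C)=CCC[C@H](C)[C@H]1c2cc(C(=O)NCc3ccc(Cl)cc3)c(OC(=O)C(C)(C)C)c(OC(=O)C(C)(C)C)c2[C@H](C)C[C@H]1OC(=O)C(C)(C)C`: 40000 nM
Compound 2, `CC(C)=CCC[C@H](C)[C@H]1c2cc(C(=O)O)c(OC(=O)C(C)(C)C)c(OC(=O)C(C)(C)C)c2[C@H](C)C[C@H]1OC(=O)C(C)(C)C`: 40000 nM

Both values come from an ADME assay on HEK293 cells (Homo sapiens) for inhibition, read by resazurin assay, with a stated time of 72 h; a lower number here means a stronger inhibitor, a higher number a weaker inhibitor. Compound 1 gives 40000 nM in this assay, and compound 2 gives 40000 nM. Among the measured compounds shown here, the only measured step, no change at the digits printed from compound 1 to compound 2 (within the scatter), swaps an acid for the (4-chlorobenzyl)amino amide at the carbonyl carbon and leaves the reading where it was. Compound 2 therefore stands level with compound 1 on the numbers shown, and nothing in the pair separates the two.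

The next compound, compound 3, is `CC(C)=CCC[C@H](C)[C@H]1c2cc(C(=O)O)c(O)c(OC(=O)C(C)(C)C)c2[C@H](C)C[C@H]1OC(=O)C(C)(C)C`. Its difference from compound 2 is hydrogen in place of (tert-butyl)carbonyl on an oxygen on an aromatic ring, that is, the change read one bond further out is ((tert-butyl)carbonyl)oxy to hydroxy. For the measured compounds named here, no measured step in the set touches this position, so the one step available, which is of no size beyond the scatter, bears only indirectly: it shows that the read-out of this assay has been insensitive to change at the carbonyl carbon of this core. Compound 3 is expected to sit near compound 2, with the step of no change at the digits printed from compound 2 to compound 3 (within the scatter) estimated to stay within the scatter. The estimate for compound 3 in this assay is 40000 nM, in the range 15000 nM to 90000 nM.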

Compound 3, half-maximal inhibitory concentration: 40000 nM
The estimate for compound 3 equals the measured number at the digits printed; measured number inside the range.
By their numbers in this assay, from the lowest: compounds 1, 2 and 3 (each within the scatter of the next).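

In this assay, among the compounds shown here, the step of no change at the digits printed from compound 2 to compound 3 (within the scatter) gives the first reading at an oxygen on an aromatic ring, where the earlier pair spoke only to the carbonyl carbon. Here ((tert-butyl)carbonyl)oxy gives way to hydroxy, so a group of 6 heavy atoms leaves the shared core and hydrogen, with no heavy atom, enters, yet the reading does not separate the two compounds. Two different places on the core have now each been changed once with no step beyond the scatter, and no measured evidence accounts for this result.

The compounds shown leave open whether the remaining (tert-butyl)carbonyl groups can be replaced in the same way, for example by hydrogen or by a smaller acetyl group, and whether an acetyl group would read differently from hydrogen at the position changed here. Since no step shown lies beyond the scatter, they also do not identify any change on this core that moves the reading, and an amine or a longer chain in place of the hydroxy on the carbonyl carbon would test that position further.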